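The source may hold more compounds than are shown below. What is called first, only, known or untested is meant among the compounds shown, and "the series" means these compounds.

Compounds measured in a functional assay on K562 cells (Homo sapiens) for cytotoxicity, with a stated time of 72 h; a lower number here means a stronger inhibitor, a higher number a weaker inhibitor:
- compound 1 `CCc1cccc(-c2nn3c(c2-c2ccncc2)C(C)C(C)(C)C3)n1`: > 100000 nM, a limit of the assay
- compound 2 `Cc1cccc(-c2nn3c(c2-c2ccnc(Cl)c2)C(C)C(C)(C)C3)n1`: > 100000 nM, a limit of the assay
- compound 3 `CCc1cccc(-c2nn3c(c2-c2ccnc(Nc4ccc(S(N)(=O)=O)cc4)c2)C(C)C(C)(C)C3)n1`: 24000 nM

Of these three, only compound 3 has an actual number, 24000 nM. Compound 1 and compound 2 share (the limit of > 100000 nM in this assay, at which 2 of the 3 values shown sit), which is a limit and not a measured number.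

The next compound to consider is compound 4 `CCc1cccc(-c2nn3c(c2-c2ccnc(Cl)c2)C(C)C(C)(C)C3)n1`. It is made from compound 3 by putting chloro in place of (4-sulfamoylphenyl)amino on an aromatic carbon, (chloro in place of (4-sulfamoylphenyl)amino on an aromatic carbon).

For the measured compounds named here, one measured step bears directly on this change. When the same (4-sulfamoylphenyl)amino group replaced hydrogen on an aromatic carbon, the result was an at least 4.1-fold lower number from compound 1 to compound 3 (0.61 log units; beyond the scatter). Removing that group again should therefore lose this gain, even though chloro rather than hydrogen takes its place. Compound 2 also carries chloro in place of that group. Compound 2 gives > 100000 nM, again a limit.

A higher number is therefore expected, of at least modest size, and the assay may well report only a limit. The expected change is a 4.2-fold higher number from compound 3 to compound 4 (0.62 log units; beyond the scatter). For compound 4 the estimated value is 100000 nM, with an expected range from 50000 nM to 200000 nM.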

Compound 4, half-maximal inhibitory concentration: 82000 nM
Beside the measured number, compound 4's estimate is 1.2-fold (0.09 log units) above it; the measured number falls inside the stated range.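

In this assay, chloro in place of (4-sulfamoylphenyl)amino on an aromatic carbon now gives a step with a measured number at both ends: a 3.4-fold higher number from compound 3 to compound 4 (0.53 log units; beyond the scatter). Until now, the effect of (4-sulfamoylphenyl)amino at this aromatic carbon was known only as a minimum, set against a compound at the limit of the assay. In this assay compound 4 gives a real number, 82000 nM. Two further steps give only a floor: an at least 1.2-fold lower number from compound 2 to compound 4 (0.08 log units; that floor lies within the scatter), with methyl in place of hydrogen on a saturated chain carbon bound to an aromatic carbon, and an at least 1.2-fold lower number from compound 1 to compound 4 (0.08 log units; that floor lies within the scatter), with chloro in place of hydrogen on an aromatic carbon. The sizes of these two steps cannot be read, because compound 1 and compound 2 give only a limit and not a measured number: the limit of > 100000 nM in this assay, at which 2 of the 4 values shown sit.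

The compounds shown leave open whether the whole (4-sulfamoylphenyl)amino group is needed for the lower number in compound 3, or whether a plain amine, or a phenylamino group without the sulfamoyl part, would do the same at this position. For the compounds shown here, they also leave open how the chain on the other aromatic ring affects the number once a measured compound stands on each side, for example with a longer chain in place of the one in compound 4.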